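Replacing the 3,4-dimethoxyphenyl group of compound 1

This account rests on a few compounds, and the source may have more. Where it says the series, first, only, none or still open, it means among the compounds named here.

Within the data shown here, in a functional assay on MDA-MB-231 cells (Homo sapiens) for cytotoxicity, read by MTT assay, with a stated time of 72 h (on this read-out higher numbers stand for weaker inhibition and lower numbers for stronger inhibition), compound 1 (`COc1ccc(NC(=O)CN2CCN(c3nnc(Cc4ccncc4)c4ccccc34)CC2)cc1OC`) gives 100 nM as the lower of the two numbers so far. Compound 2 (`O=C(CN1CCN(c2nnc(Cc3ccccc3)c3ccccc23)CC1)Nc1c(F)cccc1F`) gives 5490 nM and sits beyond the usual scatter from compound 1. Compound 3 (`Cc1ccc(NC(=O)CN2CCN(c3nnc(Cc4ccncc4)c4ccccc34)CC2)c(C)c1`) remains unmeasured. It carries 2,4-dimethylphenyl in place of 3,4-dimethoxyphenyl on an amide-type nitrogen. Among the measured compounds shown here, no measured pair differing in one place is available, so the data give no direct guide to the size of this change in this assay. For the measured compounds named here, with compound 1 at 100 nM as the only low number, a moderate move toward weaker inhibition, just beyond the scatter, is expected rather than a further gain. The estimated size is a 4.0-fold higher number from compound 1 to compound 3 (0.60 log units; beyond the scatter) in that direction. For compound 3 the expected value is 400 nM (estimated range 90 nM to 1800 nM).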

Compound 3, half-maximal inhibitory concentration: 240 nM
Compound 3: middle estimate off by 1.7-fold (0.22 log units), on the high side, within the range that was stated.
By their numbers in this assay, from the lowest: compound 1; then compound 3; then compound 2.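

Among these compounds, this is the first single-place comparison, and it bears on the aryl group on the amide-type nitrogen. In this assay, 2,4-dimethylphenyl in place of 3,4-dimethoxyphenyl costs only a modest step (a 2.4-fold higher number from compound 1 to compound 3 (0.38 log units; beyond the scatter)), so this position still gives a number in the same low range when the group carries no oxygen and no hydrogen-bond acceptors. Nothing shown explains the step.

Because the group type and the substitution pattern change together, the step cannot be assigned to either one alone; 3,4-dimethylphenyl or 2,4-dimethoxyphenyl would separate the two. Also open, going by these compounds, is how this position responds to a different kind of group, such as an unsubstituted phenyl or a phenyl bearing a carboxylic acid or an amine.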